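The source may hold more compounds than are shown below. What is called first, only, known or untested is meant among the compounds shown, and "the series" means these compounds.

The starting point is compound 3 `CC(C)C(c1cnc(N)s1)c1ccc(-c2ccc3cccc(F)c3c2)[nH]c1=O`. In a functional assay on CHO cells for antagonist activity at prostaglandin E2 receptor EP3 subtype (Homo sapiens), read by cAMP accumulation (a higher number here means a weaker inhibitor, a lower number a stronger inhibitor), compound 3 gives 39 nM. That is the lowest of the three numbers recorded so far. The nearest is compound 2 `CCn1ncc2c(F)cc(-c3ccc(C(CC)(CC)c4nnc(C)[nH]4)c(=O)[nH]3)cc21`, which in this assay gives 90 nM, a gap beyond the usual scatter of repeated measurements. The furthest is compound 1 `CC(C)C(O)(C(=O)O)c1ccc(-c2ccc3ccccc3c2)[nH]c1=O`, which in this assay gives 1580 nM, a gap far beyond the scatter. Compound 3 is thus the strongest inhibitor among the three measured compounds.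

The next compound is compound 4 `CC(C)C(/C=C1\CCNC1=O)c1ccc(-c2ccc3cccc(F)c3c2)[nH]c1=O`, which has not yet been measured in this assay. It differs from compound 3 in one place: a group of 7 heavy atoms (5 carbon, 1 nitrogen, 1 oxygen; one five-membered non-aromatic ring with 1 hetero atom) in place of a group of 6 heavy atoms (3 carbon, 2 nitrogen, 1 sulfur; one five-membered aromatic ring with 2 hetero atoms), on a saturated chain carbon bound to an aromatic carbon and a saturated chain carbon. For the measured compounds named here, no step between two measured compounds isolates such an exchange, and nothing resembling the entering group appears among the measured compounds, so there is no direct guide to how the number will move.

The expectation for compound 4 is therefore a modest step toward a higher number, that is toward a weaker inhibitor, with wide uncertainty. The step from compound 3 to compound 4 in this assay is expected to be a 2.6-fold higher number from compound 3 to compound 4 (0.41 log units; beyond the scatter). For compound 4 in this assay the estimate is 100 nM, with a range from 25 nM to 400 nM.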

Compound 4, half-maximal inhibitory concentration: 8.7 nM
Estimate against measurement, compound 4: 11-fold (1.06 log units) above; measured number below the stated range.
By their numbers in this assay, from the lowest: compound 4; then compound 3; then compound 2; then compound 1.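

At the saturated chain carbon bound to an aromatic carbon and a saturated chain carbon, the 2-amino-1,3-thiazol-5-yl group is not required for a low number in this assay: with the rest of the molecule unchanged, a five-membered non-aromatic ring with 2 double bonds outside aromatic rings in its place gives a 4.5-fold lower number from compound 3 to compound 4 (0.65 log units; beyond the scatter), a step beyond the usual scatter. The exchange alters several features at once, since the aromatic ring and the sulfur leave, an oxygen enters, and the count of hydrogen-bond acceptors falls from 3 to 1 while the single hydrogen-bond donor count stays the same, so this one step cannot show which of these features goes with the lower number. No measurement here bears on why the number fell.

Still open, on these data alone, is whether the ring is needed at all at this carbon, which an open-chain primary amide could test, and how a six-membered lactam would compare. The role of the double bond joining the ring to the chain is also unsettled, and a plain methylene link in its place would address that.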